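Replacing tert-butoxy with methylimidazolyl at the ring position

The source may report more compounds than this note shows. Statements on the series, on what has been measured and on what is new or still open speak of the compounds shown alone.

For the measured compounds named here, compound 2 `Cc1cc(OC(C)(C)C)c(S(C)(=O)=O)cc1C(=O)N=C(N)N` gives 9.4 nM in a functional assay for inhibition of sodium/hydrogen exchanger (Oryctolagus cuniculus) (a lower number here means a stronger inhibitor, a higher number a weaker inhibitor), the lowest of the two numbers measured so far. Its nearest neighbour is compound 1 `Cc1cc(C2CCCCC2)c(S(C)(=O)=O)cc1C(=O)N=C(N)N`, which in this assay gives 22 nM, and the step of a 2.3-fold lower number from compound 1 to compound 2 (0.37 log units; beyond the scatter) was modest. Compound 3 `Cc1cc(-n2ccnc2C)c(S(C)(=O)=O)cc1C(=O)N=C(N)N` differs from compound 2 by 2-methyl-1H-imidazol-1-yl in place of tert-butoxy on an aromatic carbon. Going by the values given here, only that single step at this position bears on the change, and it was small, so a modest step in either direction, or none beyond the scatter, is expected. Compound 3 is estimated at 25 nM, between 8 nM and 80 nM. That estimate corresponds to an expected step of a 2.7-fold higher number from compound 2 to compound 3 (0.42 log units; beyond the scatter).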

Compound 3, half-maximal inhibitory concentration: 29 nM
Estimate against measurement, compound 3: 1.2-fold (0.06 log units) below, within the range that was stated.
By their numbers in this assay, from the lowest: compound 2; then compounds 1 and 3 (each within the scatter of the next).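

The position accepts a five-membered aromatic ring with two nitrogens, though the swap from the ether brings a 3.1-fold higher number from compound 2 to compound 3 (0.49 log units; beyond the scatter) and leaves tert-butoxy ahead of it. Against the cyclohexyl group, the same ring gives a 1.3-fold higher number from compound 1 to compound 3 (0.12 log units; within the scatter) and so cannot be told apart from it, which means that ring and carbocycle serve about equally here. Nothing available explains either step.

Still open, from the compounds shown here alone, is whether the methyl on the imidazole matters, which plain 1H-imidazol-1-yl would test. Also open, going by these compounds, is how an amine such as piperidin-1-yl or a simple methoxy would fare at this position.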